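The compounds below may be only part of what the source reports. "The series", "measured", "known", "first", "only" and "open" are said of these compounds alone.

Measured so far in a functional assay on ASPC1 cells (Homo sapiens) for inhibition, read by MTT assay, with a stated time of 72 h; a higher number here means a weaker inhibitor of growth, a lower number a stronger inhibitor of growth:
compound 1, `CC(C)(C)c1ccc(CNCCCNS(=O)(=O)c2cc(C(F)(F)F)cc(C(F)(F)F)c2)cc1`, 2700 nM
compound 2, `O=S(=O)(NCCCNCc1ccc(C(F)(F)F)cc1)c1cc(C(F)(F)F)cc(C(F)(F)F)c1`, 2000 nM

Compound 1 gives the highest of the two numbers in this assay; its nearest neighbour is compound 2, and the step of a 1.4-fold lower number from compound 1 to compound 2 (0.13 log units; within the scatter) is within the scatter, so the two values cannot be told apart.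

Compound 3, `O=S(=O)(NCCCNCc1cccc2ccccc12)c1cc(C(F)(F)F)cc(C(F)(F)F)c1`, is not yet measured. It differs from compound 1 in one place: naphthalen-1-yl in place of 4-(tert-butyl)phenyl on a saturated chain carbon bound to an amine nitrogen. For the measured compounds named here, the only measured step touches the same place, where trifluoromethyl in place of tert-butyl gave a 1.4-fold lower number from compound 1 to compound 2 (0.13 log units; within the scatter); this says little beyond that a change at that position has so far left the number about where it was. Going by the values given here, no measured step brings in a second aromatic ring at this position, so the expectation rests on compound 1 and compound 2 alone.

Compound 3 is expected to stay within the scatter of compound 1, with an estimated step of a 1.2-fold lower number from compound 1 to compound 3 (0.09 log units; within the scatter). The estimate for compound 3 in this assay is 2200 nM, with a range from 900 nM to 5500 nM.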

Compound 3, concentration for 50% growth inhibition: 21000 nM
Beside the measured number, compound 3's estimate is 9.5-fold (0.98 log units) below it; measured number outside the range, above it.
By their numbers in this assay, from the lowest: compounds 2 and 1 (each within the scatter of the next); then compound 3.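

In this assay, this position turns out to be sensitive: naphthalen-1-yl gives a 7.8-fold higher number from compound 1 to compound 3 (0.89 log units; beyond the scatter), and against 4-(trifluoromethyl)phenyl it gives an 11-fold higher number from compound 2 to compound 3 (1.02 log units; beyond the scatter). The earlier exchange of tert-butyl for trifluoromethyl showed no such shift, whereas replacing either substituted phenyl group on the saturated chain carbon bound to an amine nitrogen with naphthalen-1-yl weakens growth inhibition, even though 4-(tert-butyl)phenyl and naphthalen-1-yl have the same count of heavy atoms. Nothing available accounts for this loss.

Going by these compounds, it remains open whether the higher number follows from the second aromatic ring as such or from its attachment through naphthalen-1-yl, a question that naphthalen-2-yl would address. Also open, on these data alone, is where an unsubstituted phenyl or a 4-methoxyphenyl group would fall relative to compound 1 and compound 3.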